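Chloro in Place of Hydrogen on Compound 1

The source may report more compounds than this note shows. Statements on the series, on what has been measured and on what is new or still open speak of the compounds shown alone.

Within the data shown here, compound 1, `C=C(Br)C(=O)Nc1cccc(-c2cn3nc(-c4ccccc4)sc3n2)c1`, gives 900 nM in a functional assay on FM3A cells (Mus musculus) for inhibition, read by cell counting, with a stated time of 2 days (on this read-out lower numbers stand for stronger inhibition and higher numbers for weaker inhibition), the lowest of the three numbers measured so far. Compound 2, `C=C(Br)C(=O)Nc1cccc(-c2cn3c(-c4ccccc4)csc3n2)c1`, gives 1300 nM in this assay, which lies within the scatter of compound 1, so no order between the two is claimed. Compound 3, `Nc1cccc(-c2cn3nc(-c4ccccc4)sc3n2)c1`, gives 14000 nM in this assay; the step of a 16-fold higher number from compound 1 to compound 3 (1.19 log units; beyond the scatter) shows that removing the (1-bromoethenyl)carbonyl from the nitrogen on the aromatic ring costs a great deal. Compound 4, `C=C(Br)C(=O)Nc1cccc(-c2cn3nc(-c4ccc(Cl)cc4)sc3n2)c1`, differs from compound 1 by chloro in place of hydrogen on an aromatic carbon; cut one bond further out, the change reads phenyl to 4-chlorophenyl. Among the measured compounds shown here, no measured step touches the phenyl; the only step known concerns the (1-bromoethenyl)carbonyl on the nitrogen, which compound 4 keeps intact. For the measured compounds named here, with no step bearing on this change, the step of a 1.3-fold lower number from compound 1 to compound 4 (0.11 log units; within the scatter) is expected to stay within the scatter. Compound 4 is therefore estimated to give 700 nM in this assay, with a range from 250 nM to 2000 nM.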

Compound 4, half-maximal inhibitory concentration: 2000 nM
Estimate against measurement, compound 4: 2.9-fold (0.46 log units) below; low and high end bracket the measured number.
By their numbers in this assay, from the lowest: compounds 1, 2 and 4 (each within the scatter of the next, the first and the last beyond it); then compound 3.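

The phenyl of compound 1 is not a silent place: in this assay, chloro in place of hydrogen on an aromatic carbon, para to a large group, gives a 2.2-fold higher number from compound 1 to compound 4 (0.35 log units; beyond the scatter). Among these compounds, this is the first measured step at this position, and it is a modest one beside a 16-fold higher number from compound 1 to compound 3 (1.19 log units; beyond the scatter), the large step seen on removing the (1-bromoethenyl)carbonyl that compound 4 keeps. No evidence is available to explain the step at the phenyl.

The compounds shown leave open whether a different group on the same aromatic carbon, such as fluoro, methoxy, an amine or a carboxylic acid, would move the number in the same direction. They also leave open whether chloro placed elsewhere on the phenyl would give a step of similar size.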